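The source may report more compounds than this note shows. Statements on the series, on what has been measured and on what is new or still open speak of the compounds shown alone.

Series notes. Within the data shown here, compound 2 `CN1CCN(c2ccc(C3=NN(C(=O)c4ccc(F)cc4)C(c4ccc(N(C)C)cc4)C3)cc2)CC1` gives 32.2% in a functional assay on NCI-H1975 cells (Homo sapiens) for inhibition, read by sulforhodamine B assay, tested at 10 uM (on this read-out higher numbers stand for more inhibition at the one concentration tested (going by the name of the read-out) and lower numbers for less inhibition), the higher of the two numbers measured so far; its nearest neighbour, compound 1 `CN1CCN(c2ccc(C3=NN(C(=O)CCCl)C(c4ccc(N(C)C)cc4)C3)cc2)CC1`, gives -0.2%. Among the measured compounds shown here, the one step measured to date, a number 32.4 percentage points higher from compound 1 to compound 2 (beyond the scatter), came with 4-fluorophenyl in place of 2-chloroethyl on a carbonyl carbon, a replacement of the whole group rather than a change within it. Compound 3 `CN1CCN(c2ccc(C3=NN(C(=O)c4ccc(C(F)(F)F)cc4)C(c4ccc(N(C)C)cc4)C3)cc2)CC1` is not yet measured. It differs from compound 2 by trifluoromethyl in place of fluoro on an aromatic carbon. For the measured compounds named here, no measured step touches that position, so the step from compound 1 to compound 2 bears on it only in setting the level reached by the carbonyl-bound aromatic ring. With that ring kept in compound 3, the step of a number 2.2 percentage points lower from compound 2 to compound 3 (within the scatter) is expected to stay within the scatter. In this assay compound 3 is estimated at 30%, within 8% to 55%.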

Compound 3, a percentage reported as inhibition, at one concentration (the size of the read-out at that concentration, not a potency): 93.2%
Estimate against measurement, compound 3: 63.2 percentage points below; measured number outside the range, above it.
By their numbers in this assay, from the lowest: compound 1; then compound 2; then compound 3.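

In this assay, the group on the aromatic ring bound to the carbonyl proves to be a sensitive position: trifluoromethyl in place of fluoro, on an aromatic carbon para to a large group, gives a number 61 percentage points higher from compound 2 to compound 3 (beyond the scatter) as the step. The replacement of 2-chloroethyl on the carbonyl carbon by 4-(trifluoromethyl)phenyl now comes to a number 93.4 percentage points higher from compound 1 to compound 3 (beyond the scatter) and so the level reached depends on what the aromatic ring carries, not on the presence of the ring alone. Nothing at hand bears on why these two groups differ so widely.

From the compounds shown here alone, whether the level holds for other groups at this place, such as a nitrile, a methoxy group or an amine, stays open. Also open, going by these compounds, is whether trifluoromethyl elsewhere on the ring gives a similar reading, and how the compounds compare across concentrations, since only one was tested.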